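Sulfur for Selenium in Four Compounds Against Colon Cells

The source may hold more compounds than are shown below. What is called first, only, known or untested is meant among the compounds shown, and "the series" means these compounds.

The study compares four compounds that share a carbon with a double bond to nitrogen, flanked on both sides by an amide-type nitrogen. Compound 1 `C[Se]/C(=N\C(=O)c1ccco1)NC(=O)c1ccco1` carries a group of one carbon and one selenium on that carbon, and compound 2 `CS/C(=N\C(=O)c1ccco1)NC(=O)c1ccco1` carries methylsulfanyl in its place. Compound 3 `C[Se]/C(=N\C(=O)c1cnc2ccccc2c1)NC(=O)c1cnc2ccccc2c1` and compound 4 `CS/C(=N\C(=O)c1cnc2ccccc2c1)NC(=O)c1cnc2ccccc2c1` repeat the same pair on a different core; the difference between the core of compound 3 and the core of compound 1 is not broken down here.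

In a functional assay on HT-29 cells (Homo sapiens) for cytotoxicity, read by MTT assay, with a stated time of 72 h (a higher number here means a weaker inhibitor of growth, a lower number a stronger inhibitor of growth), compound 1 gives only a limit, > 100000 nM. Compound 2 likewise gives only a limit in this assay, > 100000 nM. Compound 3 also reaches only a limit in this assay, > 100000 nM.

The change from compound 1 to compound 2 is a group of 2 heavy atoms (1 carbon, 1 sulfur; no ring) in place of a group of 2 heavy atoms (1 carbon, 1 selenium; no ring), on a carbon with a double bond to nitrogen, and its size, a step that the two limits leave unreadable from compound 1 to compound 2, cannot be read because of the limit of > 100000 nM in this assay, at which 3 of the 3 values shown sit. The change from compound 3 to compound 4 is a group of 2 heavy atoms (1 carbon, 1 sulfur; no ring) in place of a group of 2 heavy atoms (1 carbon, 1 selenium; no ring), on a carbon with a double bond to nitrogen, the same change on the other core.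

Since every measured compound rests at the same limit, he expects the step of a number no higher from compound 3 to compound 4 (the limit leaves the size open) to leave compound 4 at that limit as well. He therefore estimates compound 4 at 100000 nM in this assay, within a range from 40000 nM to 300000 nM, while noting that the measurement itself is still to come.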

Compound 4, concentration for total growth inhibition: > 100000 nM
Compound 4 gave a limit, no number (the forecaster's own chance of this, stated with the estimate: 85%); the middle value lies on the limit itself.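

In this assay compound 4 gives > 100000 nM, which is a limit and not a number. No size can be read for the step from compound 3 to compound 4, because both compounds rest at the same limit: the limit of > 100000 nM in this assay, at which 4 of the 4 values shown sit. The compounds shown leave open whether methylsulfanyl and its selenium counterpart differ at all in this assay on either core; none of the four gives a number there.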